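Swapping Diethylamino for a Methylpiperazine on a Urea Series

This account rests on a few compounds, and the source may have more. Where it says the series, first, only, none or still open, it means among the compounds named here.

Three measured compounds share one core and differ only in the group on the outer ring of the urea. In a functional assay on A549 cells (Homo sapiens) for antiproliferative activity, read by MTT assay, with a stated time of 72 h (on this read-out higher numbers stand for weaker inhibition and lower numbers for stronger inhibition), compound 1 `O=C(Nc1ccccc1)Nc1ccc2ncnc(Nc3cccc(C(F)(F)F)c3)c2c1` reports only a limit of the assay, > 10000 nM. Compound 2 `COc1ccc(NC(=O)Nc2ccc3ncnc(Nc4cccc(C(F)(F)F)c4)c3c2)cc1`, carrying a methoxy, gives 9470 nM in this assay. Compound 3 `CCN(CC)c1ccc(NC(=O)Nc2ccc3ncnc(Nc4cccc(C(F)(F)F)c4)c3c2)cc1`, carrying a diethylamino, gives 3520 nM in this assay, the lowest of the two numbers. The measured steps are an at least 1.0-fold lower number from compound 1 to compound 2 (0.02 log units; that floor lies within the scatter), an at least 2.8-fold lower number from compound 1 to compound 3 (0.45 log units; beyond the scatter) and a 2.7-fold lower number from compound 2 to compound 3 (0.43 log units; beyond the scatter). Compound 4 `CN1CCN(c2ccc(NC(=O)Nc3ccc4ncnc(Nc5cccc(C(F)(F)F)c5)c4c3)cc2)CC1` is not yet measured; it differs from compound 3 as follows: 4-methylpiperazin-1-yl in place of diethylamino on an aromatic carbon. Going by the values given here, the two steps that reach compound 3 both install the diethylamino in place of something smaller, and none of the measured steps alters that amine once present, so no measured step bears directly on this swap of one amine for another. The expected step is therefore a 1.2-fold lower number from compound 3 to compound 4 (0.07 log units; within the scatter), no more than the usual scatter. For compound 4 the estimated value in this assay is 3000 nM, with a range from 900 nM to 10000 nM.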

Compound 4, half-maximal inhibitory concentration: 2760 nM
For compound 4 the middle estimate is 1.1-fold (0.04 log units) above the measured one; the range from low to high includes it.
By their numbers in this assay, from the lowest: compounds 4 and 3 (each within the scatter of the next); then compound 2. At a limit, above all of these: compound 1.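

In this assay, the swap gives a 1.3-fold lower number from compound 3 to compound 4 (0.11 log units; within the scatter) and so leaves the two amines indistinguishable, which shows that this position, para to a large group, accepts a six-membered ring in place of the open diethylamino group with no change beyond the scatter. The advantage over the methoxy group also persists with this second amine, as a 3.4-fold lower number from compound 2 to compound 4 (0.54 log units; beyond the scatter) shows. Compound 1 stands at a limit rather than a number, so an at least 3.6-fold lower number from compound 1 to compound 4 (0.55 log units; beyond the scatter) gives only a floor for the size of that step: the limit of > 10000 nM in this assay, at which 1 of the 4 values shown sits.

From the compounds shown here alone, whether the outer nitrogen of the ring matters remains open, and a morpholine, with an oxygen at that point, would address this. Also open, going by these compounds, is whether a group that is not an amine, such as a carboxylic acid, would give a step of similar size at this position.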